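Swapping a triazole arm for a short amine chain

The compounds below may be only part of what the source reports. "The series", "measured", "known", "first", "only" and "open" are said of these compounds alone.

Measured so far:
Compound 1, `O=C1c2c[n+]([O-])c3ccccc3c2C(=O)c2c1c1ccccc1n2Cc1cn(CC(O)CO)nn1`: in a toxicity assay on L02 cells (Homo sapiens) for cytotoxicity, read by MTT assay, with a stated time of 72 h (a higher number here means a weaker inhibitor, a lower number a stronger inhibitor), compound 1 gives 1070 nM.
Compound 2, `CCCCN1CCN(CCCCn2c3c(c4ccccc42)C(=O)c2c[n+]([O-])c4ccccc4c2C3=O)CC1`: in this assay compound 2 gives 5690 nM.
Compound 3, `O=C1c2c[n+]([O-])c3ccccc3c2C(=O)c2c1c1ccccc1n2Cc1cn([C@H]2C[C@H](O)[C@@H](CO)O2)nn1`: in this assay compound 3 gives 280 nM.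

Compound 1 stands second highest of the three numbers, with compound 3 below it and compound 2 above it. The unmeasured compound 4, `CN(C)CCCCn1c2c(c3ccccc31)C(=O)c1c[n+]([O-])c3ccccc3c1C2=O`, differs from compound 1 in one place: 3-(dimethylamino)propyl in place of 1-(2,3-dihydroxypropyl)-1H-1,2,3-triazol-4-yl on a saturated chain carbon bound to an aromatic nitrogen. Among the measured compounds shown here, the only step measured, a 3.8-fold lower number from compound 1 to compound 3 (0.58 log units; beyond the scatter), alters the group attached to the triazole rather than removing the triazole itself, so it does not bear directly on this change. Compound 2, whose chain on the shared core most resembles that of compound 4, shows a higher number than compound 1. Compound 4 is therefore expected to give a higher number than compound 1, an estimated 2.8-fold higher number from compound 1 to compound 4 (0.45 log units; beyond the scatter), landing at about 3000 nM (range 1200 nM to 8000 nM).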

Compound 4, half-maximal inhibitory concentration: 300 nM
Beside the measured number, compound 4's estimate is 10-fold (1.00 log units) above it, outside the stated range (below it).
By their numbers in this assay, from the lowest: compounds 3 and 4 (each within the scatter of the next); then compound 1; then compound 2.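

Removing the triazole arm does not raise the number in this assay: putting 3-(dimethylamino)propyl in its place gives a 3.6-fold lower number from compound 1 to compound 4 (0.55 log units; beyond the scatter). The far end of the chain carries a bigger step, since dimethylamino in place of 4-butylpiperazin-1-yl gives a 19-fold lower number from compound 2 to compound 4 (1.28 log units; beyond the scatter). Nothing available explains either step.

Still open, on these data alone, is how other ends on this chain would compare, such as a diethylamino group, a morpholine ring or a free primary amine. Also open, as far as these compounds go, is how a shorter or longer chain carrying the same dimethylamino group would read.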